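Replacing the arylsulfonate of compound 1 with an alkyl chain

The source may hold more compounds than are shown below. What is called first, only, known or untested is meant among the compounds shown, and "the series" means these compounds.

Compound 1 `CNC(=O)/C=C1/COc2cc(OS(=O)(=O)c3ccc(Cl)cc3)ccc21` is one of three sulfonate esters of a shared core tested in an assay (strain Sprague-Dawley) for inhibition of Amine oxidase [flavin-containing] A (Rattus norvegicus), read by spectrophotometry, with a stated time of 5 min; on this read-out lower numbers stand for stronger inhibition and higher numbers for weaker inhibition. Compound 1 gives 12 nM, the second highest of the three numbers. Compound 2 `CNC(=O)/C=C1/COc2cc(OS(=O)(=O)c3ccc(S(C)(=O)=O)cc3)ccc21` gives 19 nM, and the change a 1.6-fold higher number from compound 1 to compound 2 (0.20 log units; within the scatter). Compound 3 `CNC(=O)/C=C1/COc2c1ccc(OS(=O)(=O)c1ccc(OC)cc1)c2C` differs from compound 1 in several places. Compound 3 gives 7 nM. Compound 4 `CNC(=O)/C=C1/COc2cc(OS(=O)(=O)CCC(F)(F)F)ccc21` carries 3,3,3-trifluoropropyl in place of 4-chlorophenyl on a sulfonyl sulfur. Within the data shown here, no measured step exchanges the aromatic ring on the sulfonyl sulfur for a chain, so only the small step from compound 1 to compound 2 hints at how tolerant this position is. Compound 4 is therefore expected to show a 2.1-fold higher number from compound 1 to compound 4 (0.32 log units; beyond the scatter), a modest weakening at most. The estimate for compound 4 is 25 nM, within 8 nM to 80 nM.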

Compound 4, half-maximal inhibitory concentration: 9.1 nM
The estimate for compound 4 lay 2.7-fold (0.44 log units) above the measured number; low and high end bracket the measured number.
By their numbers in this assay, from the lowest: compounds 3, 4, 1 and 2 (each within the scatter of the next, the first and the last beyond it).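

In this assay the change to 3,3,3-trifluoropropyl in place of 4-chlorophenyl on a sulfonyl sulfur gives a 1.3-fold lower number from compound 1 to compound 4 (0.12 log units; within the scatter) and so shows that this position keeps its number with no aromatic ring on the sulfur. The earlier step altered only a group on that ring, whereas this one removes the ring itself. Nothing available here explains why the ring and the chain read alike. On these data alone, whether a plain propyl chain, a longer chain or an amine on the sulfonyl sulfur would do the same remains open. Also open, as far as these compounds go, is what part the fluorine atoms of compound 4 play.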